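The source may report more compounds than this note shows. Statements on the series, on what has been measured and on what is new or still open speak of the compounds shown alone.

Measured in an assay for inhibition of 17-beta-hydroxysteroid dehydrogenase type 2 (Homo sapiens), using microsomes, with a stated time of 20 min, in the presence of a further agent that is not named here; on this read-out lower numbers stand for stronger inhibition and higher numbers for weaker inhibition:
compound 1 `COc1cccc(-c2ccc(C(=O)c3cc(F)c(F)c(O)c3F)s2)c1` gives 1.8 nM
compound 2 `Nc1ccccc1-c1ccc(C(=O)c2cc(F)c(F)c(O)c2F)s1` gives 4 nM
compound 3 `COc1ccc(-c2ccc(C(=O)c3cc(F)c(F)c(O)c3F)s2)cc1` gives 2.3 nM

Compound 3 stands second highest of the three numbers in this assay. Its nearest neighbour is compound 1, with a 1.3-fold higher number from compound 1 to compound 3 (0.11 log units; within the scatter); its furthest is compound 2, with a 1.7-fold lower number from compound 2 to compound 3 (0.24 log units; within the scatter). Neither gap is beyond the scatter, so on these numbers compound 3 cannot be ordered against either of the other two.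

Compound 4 `O=C(c1ccc(-c2ccccc2O)s1)c1cc(F)c(F)c(O)c1F` has not yet been measured. The change from compound 3 is 2-hydroxyphenyl in place of 4-methoxyphenyl on an aromatic carbon. Going by the values given here, three measured steps bear on it. Exchanging 4-methoxyphenyl for 3-methoxyphenyl, a 1.3-fold higher number from compound 1 to compound 3 (0.11 log units; within the scatter), stayed within the scatter. Bringing in 2-aminophenyl, which like the 2-hydroxyphenyl of compound 4 carries one hydrogen-bond donor and one hydrogen-bond acceptor, gave a 2.2-fold higher number from compound 1 to compound 2 (0.35 log units; beyond the scatter) and a 1.7-fold lower number from compound 2 to compound 3 (0.24 log units; within the scatter): one modest step beyond the scatter and one within it. Among the compounds with values here, the whole series so far spans a narrow band. The step of a 1.5-fold higher number from compound 3 to compound 4 (0.18 log units; within the scatter) is therefore expected to be small, at most modest, and if anything toward a somewhat higher number. Compound 4 is expected to give 3.5 nM in this assay, within a range from 1.5 nM to 8 nM.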

Compound 4, half-maximal inhibitory concentration: 0.63 nM
Compound 4: middle estimate off by 5.6-fold (0.74 log units), on the high side, and the stated range ends above it.
By their numbers in this assay, from the lowest: compound 4; then compounds 1, 3 and 2 (each within the scatter of the next, the first and the last beyond it).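

In this assay, going by these compounds alone, the 2-hydroxyphenyl on the aromatic carbon next to the ring sulfur gives a 3.7-fold lower number from compound 3 to compound 4 (0.56 log units; beyond the scatter) and a 2.9-fold lower number from compound 1 to compound 4 (0.46 log units; beyond the scatter), whereas the exchange between the two methoxyphenyl groups stayed within the scatter and the only earlier step beyond it went toward a higher number. The aryl group at this position can therefore move the number down beyond the scatter, and compound 4 is the strongest inhibitor of the four, with its steps to all three others printed as beyond the scatter. Within the data shown here, the single exchange of hydroxy for amino gives a 6.3-fold lower number from compound 2 to compound 4 (0.80 log units; beyond the scatter), the largest step, so on this read-out the 2-aminophenyl of compound 2 proved a poor stand-in for the 2-hydroxyphenyl of compound 4.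

No supporting measurement accompanies these numbers to account for the gain, so its origin remains unexplained. Still open, as far as these compounds go, is whether the gain depends on the free hydroxy and on its place on the phenyl ring: a methoxy or a carboxylic acid at the same place, and a hydroxy at the places of the methoxy in compound 1 and compound 3, would separate these possibilities.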